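Methoxy to Chloro on the Aryl Ring: Forecasting Compound 3

A few compounds are considered here, and "the series" means these few. Any claim that something is new, unique, unknown or untested is made for them only; others in the source may bear on it.

Compound 1 `Cc1nc2ccccc2c(=O)n1NC(=O)/C(Cl)=C/c1ccccc1` gives 50 nM in a functional assay on SF-268 cells (Homo sapiens) for inhibition, read by sulforhodamine B assay, with a stated time of 48 h; on this read-out higher numbers stand for weaker inhibition of growth and lower numbers for stronger inhibition of growth. Compound 2 `COc1ccc(/C=C(\Cl)C(=O)Nn2c(C)nc3ccccc3c2=O)cc1` gives 800 nM in this assay.

Compound 2 stands highest of the two numbers; its nearest neighbour is compound 1, and the step of a 16-fold higher number from compound 1 to compound 2 (1.20 log units; beyond the scatter) separates them. Compound 3 `Cc1nc2ccccc2c(=O)n1NC(=O)/C(Cl)=C/c1ccc(Cl)cc1` differs from compound 2 by chloro in place of methoxy on an aromatic carbon. Among the compounds with values here, no measured step covers this exchange; only a 16-fold higher number from compound 1 to compound 2 (1.20 log units; beyond the scatter) touches the same position, showing that a methoxy there raised the number a great deal. Chloro is a different group, so compound 3 is expected to sit between the two, a moderate fall a 3.2-fold lower number from compound 2 to compound 3 (0.51 log units; beyond the scatter). Compound 3 is therefore estimated at 250 nM, within 60 nM to 1000 nM.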

Compound 3, concentration for 50% growth inhibition: 50800 nM
Compound 3: middle estimate off by 200-fold (2.31 log units), on the low side, and the stated range ends below it.
By their numbers in this assay, from the lowest: compound 1; then compound 2; then compound 3.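

In this assay, chloro on this aromatic carbon does not win back what methoxy lost, and the change gives a 64-fold higher number from compound 2 to compound 3 (1.80 log units; beyond the scatter) in a further rise. Measured against hydrogen at the same carbon, chloro gives a 1000-fold higher number from compound 1 to compound 3 (3.01 log units; beyond the scatter) and so costs far more than methoxy, placing the three compounds in the order hydrogen, methoxy, chloro. No evidence is available to explain this order.

Going by these compounds, whether a fluoro or an amine on this carbon would stay close to hydrogen remains open. So does whether chloro would raise the number as sharply elsewhere on the ring.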